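Shortening the Alkyl Chain of Compound 2

A few compounds are considered here, and "the series" means these few. Any claim that something is new, unique, unknown or untested is made for them only; others in the source may bear on it.

Compound 1 `CCCCCCCCC[C@@]1(CO)NC[C@H](O)[C@H]1O`: 960 nM
Compound 2 `CCCCCCCCC[C@]1(CO)NC[C@@H](O)[C@@H]1O`: 66000 nM
Compound 3 `OC[C@]1(c2cccc(F)c2)NC[C@H](O)[C@H]1O`: 43000 nM

All three were tested in an assay on isolated protein for inhibition of lysosomal alpha-glucosidase (Rattus norvegicus), read by colorimetric assay; a higher number here means a weaker inhibitor, a lower number a stronger inhibitor. Compound 2 has the highest number of the three; compound 3 lies within the scatter of it, while compound 1 stands far lower, with a 69-fold higher number from compound 1 to compound 2 (1.84 log units; beyond the scatter), a step that rests only on (the fact that compounds 1 and 2 differ only in the configuration as drawn). Compound 4 `CCCC[C@]1(CO)NC[C@@H](O)[C@@H]1O` is obtained from compound 2 by hydrogen in place of pentyl on a saturated chain carbon, four bonds along the chain from a saturated ring carbon. Among the compounds with values here, no measured step bears directly on this change: the one step available concerns configuration, not chain length, and compound 3 differs from compound 2 in more than one place. The expectation is therefore wide and leans toward a weaker inhibitor. Compound 4 is estimated at 150000 nM, with a range from 40000 nM to 600000 nM. This amounts to an expected 2.3-fold higher number from compound 2 to compound 4 (0.36 log units; beyond the scatter) in this assay.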

Compound 4, half-maximal inhibitory concentration: 16000 nM
Compound 4: the middle estimate sits 9.4-fold (0.97 log units) above what was measured, outside the stated range (below it).
By their numbers in this assay, from the lowest: compound 1; then compound 4; then compounds 3 and 2 (each within the scatter of the next).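

In this assay, within the data shown here, the first measured change of chain length at this position gives a 4.1-fold lower number from compound 2 to compound 4 (0.62 log units; beyond the scatter), so in this configuration inhibition does not depend on keeping the pentyl part of the chain, and the shorter chain does better. With only these two compounds, this is one step and not a trend. Nothing at hand explains the gain.

From the compounds shown here alone, whether a shorter chain still, or a chain ending in an amine, would lower the number further remains open. So does whether the same shortening would act alike in the configuration of compound 1.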